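Thiophene for furan on the shared core

This account rests on a few compounds, and the source may have more. Where it says the series, first, only, none or still open, it means among the compounds named here.

Of the compounds shown here, two have been read in a functional assay on HepG2 cells (Homo sapiens) for antiproliferative activity, read by XTT assay, with a stated time of 72 h; on this read-out higher numbers stand for weaker inhibition and lower numbers for stronger inhibition. Compound 1 `CSc1ncnc2c1c(-c1ccsc1)cn2[C@@H]1O[C@H](CO)[C@@H](O)[C@H]1O` returns only a limit of the assay, > 15000 nM. For the measured compounds named here, compound 2 `CN(C)c1ncnc2c1c(-c1ccoc1)cn2[C@@H]1O[C@H](CO)[C@@H](O)[C@H]1O` gives 12500 nM, the only actual number so far. Compound 3 `CN(C)c1ncnc2c1c(-c1ccsc1)cn2[C@@H]1O[C@H](CO)[C@@H](O)[C@H]1O` carries thiophen-3-yl in place of furan-3-yl on an aromatic carbon. Going by the values given here, no measured pair isolates this change, so in this assay no shift beyond the scatter is expected, in either direction. The estimated step is a 1.0-fold lower number from compound 2 to compound 3 (0.02 log units; within the scatter). For compound 3 the estimated value is 12000 nM, with an expected range of 5000 nM to 26000 nM.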

Compound 3, half-maximal inhibitory concentration: > 20000 nM
Compound 3 ended at the assay's limit; the forecaster's own chance of this, stated with the estimate: 40%; middle value at least 1.6-fold (0.22 log units) from the limit.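

In this assay, thiophen-3-yl in place of furan-3-yl on an aromatic carbon gives an at least 1.6-fold higher number from compound 2 to compound 3 (0.20 log units; that floor lies within the scatter). From the compounds shown here alone, the reading for compound 3 is a limit, so this change brings no stronger inhibition at this position, and the true size of the step stays unknown. The step for dimethylamino in place of methylsulfanyl cannot be read, as both compounds stand at limits.

Going by these compounds, it remains open whether any group at this position gives stronger inhibition than furan-3-yl. A phenyl ring here, or a primary amine in place of dimethylamino, would extend the comparison.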